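Notes on the shared core: methyl to nitro step

A few compounds are considered here, and "the series" means these few. Any claim that something is new, unique, unknown or untested is made for them only; others in the source may bear on it.

Compound 1 `Cc1ccc(-c2ccc(C)n2-c2ccc(-c3nc4ccccc4s3)cc2)cc1` gives 3100 nM in a functional assay on MCF7 cells (Homo sapiens) for cytotoxicity, read by MTT assay, with a stated time of 72 h; on this read-out lower numbers stand for stronger inhibition and higher numbers for weaker inhibition.
Compound 2 `Cc1ccc(-c2ccc(F)cc2)n1-c1ccc(-c2nc3ccccc3s2)cc1` gives 3180 nM in this assay.
Compound 3 `Cc1ccc(-c2ccc(C)n2-c2ccc(-c3nc4ccc(F)cc4s3)cc2)cc1` gives 2970 nM in this assay.

All three numbers sit together; compound 3 has the lowest, but its gaps to compound 1 and to compound 2 are within the scatter. Compound 4 `Cc1ccc(-c2ccc([N+](=O)[O-])cc2)n1-c1ccc(-c2nc3ccc(F)cc3s2)cc1` differs from compound 3 by nitro in place of methyl on an aromatic carbon. Going by the values given here, no measured step changes this methyl to nitro. Among the compounds with values here, the only step at this position, a 1.0-fold higher number from compound 1 to compound 2 (0.01 log units; within the scatter), was flat, and a 1.0-fold lower number from compound 1 to compound 3 (0.02 log units; within the scatter) elsewhere on the core was flat too. Within the data shown here, the series so far is insensitive to such ring substitution, so for compound 4 the expected step is a 1.0-fold higher number from compound 3 to compound 4 (0.00 log units; within the scatter), with a wider range for an untested group. The estimate for compound 4 is 3000 nM, between 1200 nM and 7500 nM.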

Compound 4, half-maximal inhibitory concentration: 2370 nM
Compound 4: middle estimate off by 1.3-fold (0.10 log units), on the high side; the measured number falls inside the stated range.
By their numbers in this assay, from the lowest: compounds 4, 3, 1 and 2 (each within the scatter of the next).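

In this assay, the first direct replacement of the methyl gives a 1.3-fold lower number from compound 3 to compound 4 (0.10 log units; within the scatter), so 4-methylphenyl to 4-nitrophenyl joins the earlier fluoro step at this position as a change within the scatter. This extends the flat picture from a single-atom group to nitro, on a core that also carries the fluoro of compound 3. Nothing available gives a reason for this flatness.

On these data alone, whether an amine, a carboxylic acid or a longer chain at this position would behave the same remains open. So does whether any change on the shared core can move the number beyond the scatter.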